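The source may hold more compounds than are shown below. What is called first, only, known or untested is meant among the compounds shown, and "the series" means these compounds.

In an ADME assay on Raji cells (Homo sapiens) for cytotoxicity, read by CellTiter-Glo and resazurin assay, with a stated time of 72 h (on this read-out lower numbers stand for an effect already at smaller amounts and higher numbers for an effect only at larger amounts of compound), three compounds built on a shared core have been measured, and each result is a limit rather than a number. Compound 1 `CC(C)N(Cc1cccc(OCCCCCC(=O)O)c1)C(=O)c1ccc(-c2ccncc2)cc1` gives > 26000 nM, which is a limit. Compound 2 `CCOC(=O)CCCCCOc1cccc(CN(C(=O)c2ccc(-c3cccc(NC(C)=O)c3)cc2)C(C)C)c1` likewise gives > 26000 nM, a limit. Compound 3 `CCOC(=O)CCCCCOc1cccc(CN(C(=O)c2ccc(-c3cccnc3)cc2)C(C)C)c1` stands at > 26000 nM, again a limit, so it sits exactly where all other values shown sit (the limit of > 26000 nM in this assay, at which 3 of the 3 values shown sit). For the measured compounds named here, the single measured step between compounds that differ in one place, a step that the two limits leave unreadable from compound 2 to compound 3, has a size that cannot be read, since both of its ends are limits.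

Compound 4 `CCOC(=O)CCCCCOc1cccc(CN(C(=O)c2ccc(-c3ccc4[nH]ccc4c3)cc2)C(C)C)c1` has not yet been measured in this assay. Its difference from compound 3 is 1H-indol-5-yl in place of pyridin-3-yl on an aromatic carbon. No measured step gives a readable size that bears on this change; the only step shown is unreadable, and the limit of > 26000 nM in this assay, at which 3 of the 3 values shown sit, shows that every value recorded in this assay sits at the limit. A step beyond the scatter is therefore not expected, and compound 4 is expected to land at the limit once more. The estimate for compound 4 in this assay is 30000 nM, with a range from 15000 nM to 60000 nM. This estimate means an expected step that the limit leaves unreadable from compound 3 to compound 4.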

Compound 4, half-maximal effective concentration: > 26000 nM
Compound 4 gave a limit, no number (the forecaster's own chance of this, stated with the estimate: 85%); the middle value is on the limit's open side.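

In this assay no new step can be read: the comparisons of compound 4 with compound 3 and with compound 2 both join two limits, so their sizes stay unreadable. The compounds shown leave open how far any of them lies beyond the limit, and whether any change on the shared core would give a readable number: the limit of > 26000 nM in this assay, at which 4 of the 4 values shown sit.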